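The source may hold more compounds than are shown below. What is called first, only, known or untested is meant among the compounds shown, and "the series" means these compounds.

Three compounds were measured in a functional assay on HT-29 cells (Homo sapiens) for antiproliferative activity, read by sulforhodamine B assay, with a stated time of 48 h; on this read-out lower numbers stand for stronger inhibition and higher numbers for weaker inhibition. Compound 1, `CCC(=O)Nc1cccc(S(=O)(=O)Oc2ccccc2C(C)C)c1`, gives 22000 nM. Compound 2, `CCCC(=O)Nc1cccc(S(=O)(=O)Oc2ccccc2C(C)C)c1`, gives 13000 nM. The change between them is methyl in place of hydrogen on a saturated chain carbon, two bonds along the chain from a carbonyl carbon, and it made a 1.7-fold lower number from compound 1 to compound 2 (0.23 log units; within the scatter). Compound 3, `CC(C)C(=O)Nc1ccc(S(=O)(=O)Oc2ccccc2C(C)C)cc1`, gives 14000 nM. The difference between the core of compound 3 and the core of compound 1 is not broken down here, so their two values can only be set side by side.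

Compound 4, `CC(C)c1ccccc1OS(=O)(=O)c1ccc(NC(=O)C(C)(C)C)cc1`, has not yet been measured. It differs from compound 3 by methyl in place of hydrogen on a saturated chain carbon bound to a carbonyl carbon and two saturated chain carbons. Going by the values given here, this is the same kind of change as the one from compound 1 to compound 2, but the place is not the same word for word: in compound 2 the methyl enters on a saturated chain carbon, two bonds along the chain from a carbonyl carbon, whereas in compound 4 it enters on a saturated chain carbon bound to a carbonyl carbon and two saturated chain carbons.

For compound 4 the step expected is a 1.4-fold lower number from compound 3 to compound 4 (0.15 log units; within the scatter), and this rests on a 1.7-fold lower number from compound 1 to compound 2 (0.23 log units; within the scatter), which stayed within the scatter. Compound 4 is therefore estimated to give about 10000 nM in this assay, with the expected range running from 4000 nM to 25000 nM.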

Compound 4, half-maximal inhibitory concentration: 15000 nM
Compound 4: the middle estimate sits 1.5-fold (0.18 log units) below what was measured; the measured number falls inside the stated range.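

In this assay, replacing isopropyl with tert-butyl on the amide carbonyl gives a 1.1-fold higher number from compound 3 to compound 4 (0.03 log units; within the scatter), so adding this methyl leaves no readable mark on the core of compound 3. Both steps stay within the scatter, so the data give no sign that this kind of change behaves differently on the two cores, and the gap between the steps is also too small to read: the same change on two cores in this assay, a 1.7-fold lower number (0.23 log units; within the scatter) from compound 1 to compound 2 and a 1.1-fold higher number (0.03 log units; within the scatter) from compound 3 to compound 4, 1.8-fold (0.26 log units) apart, within the scatter of two such steps. This shows only that one added methyl did not clearly move the number on either core; it does not show that the change has the same real effect on both, or that it has no effect at all, since the methyl enters at differently described places and any small real shift would be hidden in the scatter.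

The compounds shown leave open whether any change to this acyl chain can move the number beyond the scatter, for instance a longer chain, an amine or a carboxylic acid in place of the methyl. They also leave open how tert-butyl would behave on the core of compound 1, which would compare the same group on both cores directly.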